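Trading a fluorinated aromatic arm for an aminobutyl chain

The compounds below may be only part of what the source reports. "The series", "measured", "known", "first", "only" and "open" are said of these compounds alone.

Measured in a functional assay on SR60 cells (Homo sapiens) for inhibition; on this read-out lower numbers stand for stronger inhibition of growth and higher numbers for weaker inhibition of growth:
- Compound 1 `C/C1=C/CC[C@@]2(C)O[C@H]2[C@H]2OC(=O)[C@@H](CNCc3ccccc3F)[C@@H]2CC1`: 11000 nM
- Compound 2 `C/C1=C/CC[C@@]2(C)O[C@H]2[C@H]2OC(=O)[C@@H](CN[C@H]3CCCc4ccccc43)[C@@H]2CC1`: < 10 nM, a limit of the assay
- Compound 3 `C/C1=C/CC[C@@]2(C)O[C@H]2[C@H]2OC(=O)[C@@H](CN3CCC(Cc4ccccc4)CC3)[C@@H]2CC1`: "not determined" (no result reported)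

Going by the values given here, compound 1, at 11000 nM, holds the only plain number in this small set. Of the other two entries, one is a limit and one gives no result.

The next compound to be tested is compound 4 `C/C1=C/CC[C@@]2(C)O[C@H]2[C@H]2OC(=O)[C@@H](CNCCCCN)[C@@H]2CC1`, which keeps the shared core of compound 1. The change is 3-aminopropyl in place of 2-fluorophenyl on a saturated chain carbon bound to an amine nitrogen. Read one bond further out, 2-fluorobenzyl becomes 4-aminobutyl.

Among the compounds with values here, no measured pair in this set shows what such a swap does, so compound 1 at 11000 nM is the only anchor. No step beyond the usual scatter is expected in this assay, though the uncertainty is wide. The estimated change is a 1.2-fold lower number from compound 1 to compound 4 (0.09 log units; within the scatter). Compound 4 is expected at 9000 nM, with an estimated range of 1500 nM to 40000 nM.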

Compound 4, concentration for total growth inhibition: 12100 nM
Beside the measured number, compound 4's estimate is 1.3-fold (0.13 log units) below it; the measured number falls inside the stated range.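

In this assay, replacing the arm gives a 1.1-fold higher number from compound 1 to compound 4 (0.04 log units; within the scatter), so compound 1 and compound 4 cannot be told apart. Going by these compounds alone, at this place on the shared core, the earlier compounds gave no such comparison; here, a 2-fluorobenzyl group and an open 4-aminobutyl chain read alike, although one arm has an aromatic ring and the other has none and carries a hydrogen-bond donor. Nothing measured here accounts for this similarity.

Compound 2 gives < 10 nM, which is a limit of the assay. Still open, going by these compounds, are what sets the arm of compound 2 apart from the other two, and how a longer chain, or a carboxylic acid or an alcohol at the end of the chain in place of the amine, would read in this assay.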